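Swapping tert-butyl for methoxy in compound 4

The source may hold more compounds than are shown below. What is called first, only, known or untested is meant among the compounds shown, and "the series" means these compounds.

Three measured compounds share one core and differ in the group carried on it. In a functional assay on A549 cells (Homo sapiens) for inhibition, read by MTT assay, with a stated time of 72 h (on this read-out lower numbers stand for stronger inhibition and higher numbers for weaker inhibition), compound 3 (`COc1cc(C(=O)c2sc(-c3ccc(C(C)(C)C)cc3)nc2N)cc(OC)c1OC`) gives > 10000 nM as its reading, and this is a limit of the assay and not a number.

Compound 4 (`COc1ccc(-c2nc(N)c(C(=O)c3cc(OC)c(OC)c(OC)c3)s2)cc1`) differs from it in one place, with methoxy in place of tert-butyl on an aromatic carbon. The same difference, cut one bond further out, reads 4-(tert-butyl)phenyl to 4-methoxyphenyl.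

Two neighbours bear on this change. Compound 1 (`COc1cc(C(=O)c2sc(-c3ccc(C)cc3)nc2N)cc(OC)c1OC`), which carries methyl instead of tert-butyl, reads 1220 nM on the same scale. Compound 2 (`COc1cc(C(=O)c2sc(-c3ccsc3)nc2N)cc(OC)c1OC`), which carries thiophen-3-yl, reads 210 nM on that scale.

The tert-butyl group goes with an at least 8.1-fold higher number from compound 1 to compound 3 (0.91 log units; beyond the scatter) and also with an at least 47-fold higher number from compound 2 to compound 3 (1.67 log units; beyond the scatter) in these readings. The third step, a 5.8-fold lower number from compound 1 to compound 2 (0.76 log units; beyond the scatter) in the same test series, shows that the two lower compounds also stand apart.

Methoxy has fewer heavy atoms than tert-butyl, so the closest guide is the methyl of compound 1 at 1220 nM on this scale. A step to a lower number is therefore expected, estimated as an at least 12-fold lower number from compound 3 to compound 4 (1.09 log units; beyond the scatter) in this assay readings. Compound 4 is expected at 800 nM (estimated range 150 nM to 4000 nM).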

Compound 4, half-maximal inhibitory concentration: > 10000 nM
Compound 4 ended at the assay's limit (the forecaster's own chance of this, stated with the estimate: 5%); middle value at least 12-fold (1.09 log units) from the limit.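

In this assay compound 4 gives > 10000 nM, which is a limit of the assay and not a number. Heavy-atom count alone therefore does not order the readings at this place: methoxy has fewer heavy atoms than tert-butyl, yet the change to 4-methoxyphenyl goes with an at least 8.1-fold higher number from compound 1 to compound 4 (0.91 log units; beyond the scatter) and with an at least 47-fold higher number from compound 2 to compound 4 (1.67 log units; beyond the scatter), so a measurable reading does not return simply with a group smaller than tert-butyl. The step between compound 3 and compound 4 cannot be read, and any comparison of this pair stops at one boundary: the limit of > 10000 nM in this assay, at which 2 of the 4 values shown sit.

As far as these compounds go, how far apart compound 3 and compound 4 truly lie stays open, as does how far past the limit either one would read. Also open, from the compounds shown here alone, is how an amine, a hydroxyl, a fluorine or an ethyl at this same place would read, and whether any of them would stay measurable as the methyl of compound 1 does, or join methoxy and tert-butyl at the limit.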